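Swapping the amide substituent on a nitrobenzoxadiazole-linked ester

A few compounds are considered here, and "the series" means these few. Any claim that something is new, unique, unknown or untested is made for them only; others in the source may bear on it.

Measured compounds:
- compound 1 `O=C(CCC(=O)OCCCCCCSc1ccc([N+](=O)[O-])c2nonc12)Nc1cccc(Cl)c1`: 28800 nM
- compound 2 `COc1ccc(NC(=O)CCC(=O)OCCCCCCSc2ccc([N+](=O)[O-])c3nonc23)cc1`: 420 nM

Both compounds were tested in an assay on isolated protein for inhibition of glutathione S-transferase P (Homo sapiens), with a stated time of 10 min; a lower number here means a stronger inhibitor, a higher number a weaker inhibitor. Within the data shown here, compound 2 gives the lower of the two numbers, and the only step available, a 69-fold lower number from compound 1 to compound 2 (1.84 log units; beyond the scatter), shows how strongly the group on the amide-type nitrogen can move the read-out. Compound 3 `CN(C)CCCNC(=O)CCC(=O)OCCCCCCSc1ccc([N+](=O)[O-])c2nonc12` differs from compound 2 by 3-(dimethylamino)propyl in place of 4-methoxyphenyl on an amide-type nitrogen. Among the measured compounds shown here, no measured pair shows an aromatic ring being replaced by a chain at this position, so the step from compound 1 to compound 2 is only an indirect guide: it tells that this position is sensitive, not which way a chain will go. Losing the aromatic ring that both measured compounds carry is expected to cost potency, so a step of a 7.1-fold higher number from compound 2 to compound 3 (0.85 log units; beyond the scatter) is estimated. Compound 3 is therefore expected to give 3000 nM, with a range from 400 nM to 25000 nM.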

Compound 3, half-maximal inhibitory concentration: 160 nM
Estimate against measurement, compound 3: 19-fold (1.27 log units) above; the whole stated range lies above it.
By their numbers in this assay, from the lowest: compound 3; then compound 2; then compound 1.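

In this assay, an aromatic ring on the amide-type nitrogen proves unnecessary for a low number: 3-(dimethylamino)propyl, which has no ring, gives a 2.6-fold lower number from compound 2 to compound 3 (0.42 log units; beyond the scatter) and a 180-fold lower number from compound 1 to compound 3 (2.26 log units; beyond the scatter). Compound 3 therefore has the lowest number of the three, with both steps beyond the scatter, so this position accepts a chain as well as an aromatic ring. No measurement shown here accounts for the chain's advantage over either aromatic group.

As far as these compounds go, it remains open whether the gain comes from the dimethylamino group or from the propyl chain carrying it. A plain hexyl chain, a primary amine or a carboxylic acid at the same place on the amide-type nitrogen would help separate those two possibilities.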